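Adding a Dibutylamino Tail to a Trimethoxyphenyl Flavone

A few compounds are considered here, and "the series" means these few. Any claim that something is new, unique, unknown or untested is made for them only; others in the source may bear on it.

The read-out here is a functional assay on PC-3 cells (Homo sapiens) for antiproliferative activity, read by WST assay, with a stated time of 3 days; on this read-out higher numbers stand for weaker inhibition and lower numbers for stronger inhibition. Compound 1 `CCCCCCCOc1c(-c2cc(OC)c(OC)c(OC)c2)oc2ccccc2c1=O` gives only a limit in this assay, > 50000 nM (the limit of > 50000 nM in this assay, at which 1 of the 2 values shown sits). Compound 2 `CCC(C)Oc1c(-c2cc(OC)c(OC)c(OC)c2)oc2ccccc2c1=O` gives 38600 nM in this assay. Within the data shown here, the single measured step, an at least 1.2-fold lower number from compound 1 to compound 2 (0.11 log units; that floor lies within the scatter), is the only guide, and it stays within the scatter. Compound 3 `CCCCN(CCCC)CCCCCOc1c(-c2cc(OC)c(OC)c(OC)c2)oc2ccccc2c1=O` differs from compound 1 by dibutylamino in place of ethyl on a saturated chain carbon, five bonds along the chain from an oxygen on an aromatic ring. No measured step touches this part of the chain, and the shown step gives little direction. A lower number is nonetheless expected for compound 3, namely 8000 nM, with a range from 1500 nM to 50000 nM. That expected step is an at least 6.2-fold lower number from compound 1 to compound 3 (0.79 log units; beyond the scatter).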

Compound 3, half-maximal inhibitory concentration: 6800 nM
Estimate against measurement, compound 3: 1.2-fold (0.07 log units) above; measured number inside the range.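

Dibutylamino in place of ethyl on a saturated chain carbon, five bonds along the chain from an oxygen on an aromatic ring, gives an at least 7.3-fold lower number from compound 1 to compound 3 (0.86 log units; beyond the scatter). Unlike the earlier step, this one shows that a change in this place can move the read-out in this assay beyond the scatter. The true size of the step stays unknown, as compound 1 gives only a limit and not a number: the limit of > 50000 nM in this assay, at which 1 of the 3 values shown sits.

Still open, going by these compounds, is whether the nitrogen or the added carbon atoms account for the change. A smaller amine such as dimethylamino, a ring amine such as piperidine, or a carboxylic acid in this place would help to separate them, and none is among the compounds shown.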